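The source may report more compounds than this note shows. Statements on the series, on what has been measured and on what is new or still open speak of the compounds shown alone.

In a functional assay on HepG2 cells (Homo sapiens) for inhibition, read by MTT assay, with a stated time of 72 h (a lower number here means a stronger inhibitor, a higher number a weaker inhibitor), compound 1 (`O=C(Nc1cccc(C(F)(F)F)c1)C1CCN(C/C=C/c2ccccc2)CC1`) gives 11400 nM and compound 2 (`O=C(Nc1cccc(Cl)c1)C1CCN(C/C=C/c2ccccc2)CC1`) gives 20000 nM. Within the data shown here, these are the only two numbers so far, and they stand within the scatter of each other, so compound 2 cannot be ranked apart from compound 1. Compound 3 (`O=C(Nc1cccc(Br)c1)C1CCN(C/C=C/c2ccccc2)CC1`) has not yet been measured. It differs from compound 2 by bromo in place of chloro on an aromatic carbon, with bromo in place of chloro on an aromatic carbon, meta to a large group. Among the measured compounds shown here, one measured step bears on this change, as it too exchanges the group on an aromatic carbon: a 1.8-fold higher number from compound 1 to compound 2 (0.24 log units; within the scatter). For the measured compounds named here, with that step as the only guide, no change beyond the scatter is expected in this assay. The expected step is a 1.3-fold lower number from compound 2 to compound 3 (0.12 log units; within the scatter). Compound 3 is estimated at 15000 nM, with an expected range from 8000 nM to 30000 nM.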

Compound 3, half-maximal inhibitory concentration: 19200 nM
The estimate for compound 3 lay 1.3-fold (0.11 log units) below the measured number; the range from low to high includes it.
By their numbers in this assay, from the lowest: compounds 1, 3 and 2 (each within the scatter of the next).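

In this assay, among these compounds, the exchange of 3-chlorophenyl for 3-bromophenyl gives a 1.0-fold lower number from compound 2 to compound 3 (0.02 log units; within the scatter), the first direct comparison of two halogens at this place, meta to a large group. The exchange of trifluoromethyl for bromo gives a 1.7-fold higher number from compound 1 to compound 3 (0.23 log units; within the scatter), so all three groups at this place, trifluoromethyl, chloro and bromo, now stand within the scatter of one another, and this assay does not tell them apart. Nothing measured here accounts for this result.

The compounds shown leave open whether an amine, a hydroxyl or a carboxylic acid at this place would also stay within the scatter of these numbers. They also leave open how the numbers would respond to a change elsewhere, as all three compounds share the same core.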